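A few compounds are considered here, and "the series" means these few. Any claim that something is new, unique, unknown or untested is made for them only; others in the source may bear on it.

In an ADME assay on the whole organism (Mus musculus) for metabolic stability, read by LC-MS, with a stated time of 24 h (a lower number here means that the compound disappears faster, a higher number that the compound lasts longer), the results so far are:

- Compound 1 `COc1ccc(-c2ccccc2)c2ncc(NC(=O)N3CCC(C)(O)CC3)nc12`: > 2 h, a limit of the assay and not a number
- Compound 2 `COc1ccc(C2CCOCC2)c2ncc(NC(=O)N3CCC(C)(O)CC3)nc12`: 0.92 h

Within the data shown here, compound 2 gives the only true number so far, 0.92 h. For compound 1, the result is the limit of > 2 h in this assay, at which 1 of the 2 values shown sits.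

Among the measured compounds shown here, the one measured step, oxan-4-yl in place of phenyl on an aromatic carbon, gives an at least 2.1-fold lower number from compound 1 to compound 2 (0.33 log units; beyond the scatter). Compound 3 `COCCn1cc(C(=O)Nc2cnc3c(C4CCOCC4)ccc(OC)c3n2)cn1` keeps the oxan-4-yl group of compound 2 and differs elsewhere: 1-(2-methoxyethyl)-1H-pyrazol-4-yl in place of 4-hydroxy-4-methylpiperidin-1-yl on a carbonyl carbon. In words, this is 1-(2-methoxyethyl)-1H-pyrazol-4-yl in place of 4-hydroxy-4-methylpiperidin-1-yl on a carbonyl carbon.

The measured step lies at a different place in the structure, so it bears only loosely on this change and gives no direction for it. No change on the carbonyl carbon has been measured. No step beyond the scatter is therefore expected, although the uncertainty is wide, and the starting point remains compound 2 at 0.92 h. The expected result is a 1.2-fold lower number from compound 2 to compound 3 (0.06 log units; within the scatter). In this assay, compound 3 is estimated at 0.8 h, with an expected range of 0.3 h to 2 h.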

Compound 3, half-life: 0.338 h
For compound 3 the middle estimate is 2.4-fold (0.37 log units) above the measured one, within the range that was stated.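

In this assay, the carbonyl carbon proves to be a place where a change counts: 1-(2-methoxyethyl)-1H-pyrazol-4-yl in place of 4-hydroxy-4-methylpiperidin-1-yl gives a 2.7-fold lower number from compound 2 to compound 3 (0.43 log units; beyond the scatter). Among these compounds, the earlier compounds varied only the group on the aromatic carbon, so this is the first sign that the half-life also responds to the group on the carbonyl carbon, here with the oxan-4-yl group held constant. The swap changes several things at once, since a six-membered non-aromatic ring with one hydrogen-bond donor leaves and a five-membered aromatic ring with no donor and more hydrogen-bond acceptors enters, so this single step cannot show which of these features matters.

Still open, going by these compounds, is whether the shorter half-life goes with the pyrazole ring, the 2-methoxyethyl chain or the loss of the hydroxy group, a question that a 1-methyl-1H-pyrazol-4-yl group or a plain piperidin-1-yl group could help to separate. The phenyl compound 1 also gives no number to build on, as its result is a limit of the assay: the limit of > 2 h in this assay, at which 1 of the 3 values shown sits.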